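Chloro in Place of Hydrogen on the Phenyl of Compound 3

The source may hold more compounds than are shown below. What is called first, only, known or untested is meant among the compounds shown, and "the series" means these compounds.

Of the compounds shown here, three built on one shared core have been measured in a functional assay on SGC-7901 cells (Homo sapiens) for antiproliferative activity, read by MTT assay, with a stated time of 24 h; a higher number here means a weaker inhibitor, a lower number a stronger inhibitor. Compound 1 `O=c1[nH]cc(S(=O)(=O)Nc2ccccc2-c2cn(-c3ccccc3F)nn2)c(=O)[nH]1` gives 10800 nM. Compound 2 `O=c1[nH]cc(S(=O)(=O)Nc2ccccc2-c2cn(-c3cccc(F)c3)nn2)c(=O)[nH]1` reaches only a limit, > 20000 nM, in this assay. Compound 3 `O=c1[nH]cc(S(=O)(=O)Nc2cccc(-c3cn(-c4ccccc4)nn3)c2)c(=O)[nH]1` gives 17200 nM in this assay, a number that sits within the usual scatter of the value of compound 1, so the two cannot be ranked against each other. For the measured compounds named here, the one step between measured compounds, an at least 1.8-fold higher number from compound 1 to compound 2 (0.26 log units; that floor lies within the scatter), exchanges 2-fluorophenyl for 3-fluorophenyl on the aromatic nitrogen and runs into (the limit of > 20000 nM in this assay, at which 1 of the 3 values shown sits), so its true size is unknown. Compound 4 `O=c1[nH]cc(S(=O)(=O)Nc2cccc(-c3cn(-c4ccccc4Cl)nn3)c2)c(=O)[nH]1` differs from compound 3 by chloro in place of hydrogen on an aromatic carbon. Going by the values given here, that change touches the same phenyl on the aromatic nitrogen, yet no measured pair adds a halogen there rather than moving one, so the step from compound 1 to compound 2 bears on it only loosely, and no step beyond the scatter is expected. The step from compound 3 to compound 4 is estimated as a 1.1-fold lower number from compound 3 to compound 4 (0.06 log units; within the scatter). Compound 4 is accordingly expected to give about 15000 nM, between 7000 nM and 30000 nM.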

Compound 4, half-maximal inhibitory concentration: 3010 nM
Beside the measured number, compound 4's estimate is 5.0-fold (0.70 log units) above it; measured number outside the range, below it.
By their numbers in this assay, from the lowest: compound 4; then compounds 1 and 3 (each within the scatter of the next). At a limit, above all of these: compound 2.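

In this assay the swap of hydrogen for chloro gives a 5.7-fold lower number from compound 3 to compound 4 (0.76 log units; beyond the scatter) and this step lies beyond the scatter, so the phenyl on the aromatic nitrogen responds to a substituent ortho to a large group. For the compounds shown here, the earlier step on this phenyl moved a fluoro rather than adding a halogen, and it ran into a limit, so this is the first step of known size at this ring, and the first to go beyond the scatter. Nothing in the data shown accounts for the size of this step.

As far as these compounds go, whether a bromo, a methyl or a methoxy in the same place would give a similar step remains open. Also open, from the compounds shown here alone, is whether the step belongs to chloro itself, or whether fluoro in that place on the core of compound 3 would do the same.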